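The compounds below may be only part of what the source reports. "The series", "measured", "known", "first", "only" and "open" are said of these compounds alone.

Two compounds carry a number in an ADME assay on BHK cells (Mesocricetus auratus) for cytotoxicity, read by MTT assay, with a stated time of 96 h; a lower number here means that less compound is tolerated, a higher number that more compound is tolerated:
compound 1, `COc1ccc(-c2nc3cc(Cl)c(Cl)cc3[nH]2)cc1`, gives 18000 nM;
compound 2, `Cn1c(-c2ccc([N+](=O)[O-])cc2)nc2cc(C(F)(F)F)ccc21`, gives > 100000 nM.

The value of compound 2 is a limit of the assay, not a number: compound 2 sits at the limit of > 100000 nM in this assay, at which 1 of the 2 values shown sits. Among the measured compounds shown here, compound 1, by contrast, gives a number inside the measured range, so of the two values shown the one for compound 2 is the higher one.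

Compound 3, `CC(=O)Nc1ccc(-c2nc3cc(C(F)(F)F)ccc3n2C)cc1`, has not yet been measured in this assay. It differs from compound 2 in one place: acetamido in place of nitro on an aromatic carbon. For the measured compounds named here, no step between two measured compounds is available here, so the size of this change can only be guessed. The step from compound 2 to compound 3 is expected to be small, about an at least 1.2-fold lower number from compound 2 to compound 3 (0.09 log units; that floor lies within the scatter), within the usual scatter. For compound 3 the expected value in this assay is 80000 nM, with a range from 30000 nM to 200000 nM.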

Compound 3, half-maximal cytotoxic concentration: > 100000 nM
Compound 3 was reported as a limit; the forecaster's own chance of this, stated with the estimate: 55%; at least 1.2-fold (0.09 log units) between middle value and limit.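

In this assay, compound 2 and compound 3 both give a limit and not a number, so no step between them can be read: the limit of > 100000 nM in this assay, at which 2 of the 3 values shown sit.

Whether acetamido in place of nitro changes the tolerated concentration at all, and in which direction, stays open with the compounds shown.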